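This account rests on a few compounds, and the source may have more. Where it says the series, first, only, none or still open, it means among the compounds named here.

Working notes on the amide-side variants of the shared core. Compound 1 `CC(C)(C)c1ccc(C(=O)N2CCC3(CC2)C(=O)N(CC(=O)N2CCCC(C(N)=O)C2)CN3c2ccccc2)cc1` gives 16900 nM in an assay on HEK293 cells for displacement of a labelled ligand from NPC1-like intracellular cholesterol transporter 1 (Homo sapiens); a lower number here means a stronger inhibitor, a higher number a weaker inhibitor. Compound 2 `CCC1CCCN(C(=O)CN2CN(c3ccccc3)C3(CCN(C(=O)c4ccc(C(C)(C)C)cc4)CC3)C2=O)C1` gives 3900 nM. Compound 3 `CC(C)(C)c1ccc(C(=O)N2CCC3(CC2)C(=O)N(CC(=O)NCCCN)CN3c2ccccc2)cc1` gives 4200 nM, which places it second highest of the three numbers shown: it sits within the scatter of compound 2, as a 1.1-fold higher number from compound 2 to compound 3 (0.03 log units; within the scatter) shows, and it is well clear of compound 1, as a 4.0-fold lower number from compound 1 to compound 3 (0.60 log units; beyond the scatter) shows. Within the set, then, the two open-chain or plainly substituted amide groups of compound 2 and compound 3 give the same kind of number, and only the carbamoyl-bearing ring of compound 1 stands apart.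

Compound 4 `CC(C)(C)c1ccc(C(=O)N2CCC3(CC2)C(=O)N(CC(=O)NCN)CN3c2ccccc2)cc1` is the next variant. The change from compound 3 is amino in place of 2-aminoethyl on a saturated chain carbon bound to an amide-type nitrogen. Among the measured compounds shown here, no measured step alters the length of this chain, so nothing here bears on it directly; the two steps into compound 3 only show that the amide substituent can be swapped broadly without the number moving beyond a modest range. Compound 4 is therefore expected to give 6000 nM, with the range 2500 nM to 15000 nM, and the estimated step of a 1.4-fold higher number from compound 3 to compound 4 (0.15 log units; within the scatter) is expected to lie within or just beyond the scatter.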

Compound 4, half-maximal inhibitory concentration: 26500 nM
Beside the measured number, compound 4's estimate is 4.4-fold (0.65 log units) below it; the measured number lies above the stated range.
By their numbers in this assay, from the lowest: compounds 2 and 3 (each within the scatter of the next); then compounds 1 and 4 (each within the scatter of the next).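

Amino in place of 2-aminoethyl on a saturated chain carbon bound to an amide-type nitrogen is the first change here that alters only the length of this chain, and it is not neutral: the result is a 6.3-fold higher number from compound 3 to compound 4 (0.80 log units; beyond the scatter). The amide substituent can therefore no longer be read as broadly interchangeable, since the (aminomethyl)amino group gives a 6.8-fold higher number from compound 2 to compound 4 (0.83 log units; beyond the scatter), while a 1.6-fold higher number from compound 1 to compound 4 (0.20 log units; within the scatter) puts it level with the 3-carbamoylpiperidin-1-yl group, so the set now falls into two pairs, compounds 2 and 3 against compounds 1 and 4. No measurement shown accounts for this step.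

The compounds shown leave open whether the number changes steadily with chain length, as a 2-aminoethyl or 4-aminobutyl chain on the amide nitrogen would show. They also leave open whether the terminal amine matters, which a 3-hydroxypropyl or plain propyl group could test.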